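Moving the Amine One Bond Further Out

The source may report more compounds than this note shows. Statements on the series, on what has been measured and on what is new or still open speak of the compounds shown alone.

Of the compounds shown here, three built on one shared core have been tested in a functional assay on the whole organism for inhibition of sodium-dependent dopamine transporter (Mus musculus); on this read-out lower numbers stand for an effect already at smaller amounts and higher numbers for an effect only at larger amounts of compound. Compound 1 `CCCNC(=O)Nc1cccc2c1CN(C)CC2c1ccccc1` reaches only the limit of the test, > 120 mg/kg. Compound 2 `CCNCC(=O)Nc1cccc2c1CN(C)CC2c1ccccc1` gives about 60 mg/kg, and compound 3 `CCCCNCC(=O)Nc1cccc2c1CN(C)CC2c1ccccc1` gives 25 mg/kg, the lowest of the two numbers measured. The steps of an at least 2.0-fold lower number from compound 1 to compound 2 (0.30 log units; that floor lies within the scatter) and an at least 4.8-fold lower number from compound 1 to compound 3 (0.68 log units; beyond the scatter) both lower the number, and the step of a 2.4-fold lower number from compound 2 to compound 3 (0.38 log units; beyond the scatter) lowers it further.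

Compound 4 `CCNCCC(=O)Nc1cccc2c1CN(C)CC2c1ccccc1` is compound 3 with (ethylamino)methyl in place of butylamino on a saturated chain carbon bound to a carbonyl carbon. The amine nitrogen thus sits one bond further from the carbonyl, while the chain on that nitrogen is the shorter one found in compound 2. Going by the values given here, the step of a 2.4-fold lower number from compound 2 to compound 3 (0.38 log units; beyond the scatter) shows that lengthening the chain on the nitrogen lowered the number, so taking it back should raise the number; no measured pair tells what moving the nitrogen outward does. A modest rise is therefore expected, with an expected step of a 1.8-fold higher number from compound 3 to compound 4 (0.26 log units; within the scatter). Compound 4 is expected to give 45 mg/kg, within a range from 20 mg/kg to 110 mg/kg.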

Compound 4, dose for half-maximal effect: 190 mg/kg
The estimate for compound 4 lay 4.2-fold (0.63 log units) below the measured number; the measured number lies above the stated range.
By their numbers in this assay, from the lowest: compound 3; then compound 2; then compound 4.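

Going by these compounds alone, with the ethyl group on the nitrogen unchanged, moving the amine one bond further from the carbonyl gives a 3.2-fold higher number from compound 2 to compound 4 (0.50 log units; beyond the scatter), so in this assay the place of the nitrogen matters as well as the chain it carries, which the earlier compounds could not show. Shortening the chain and moving the nitrogen together give a 7.6-fold higher number from compound 3 to compound 4 (0.88 log units; beyond the scatter), so the gain from the butylamino chain does not offset the outward move. The step from compound 1 to compound 4 cannot be read: the limit of > 120 mg/kg in this assay, at which 1 of the 4 values shown sits.

Still open, on these data alone, is whether a 2-(butylamino)ethyl group would bring the number down again, since the butyl chain appears here only with the nitrogen one bond nearer the carbonyl. Also open, as far as these compounds go, is how a 3-(ethylamino)propyl group, with the nitrogen further out still, would read.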